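This account rests on a few compounds, and the source may have more. Where it says the series, first, only, none or still open, it means among the compounds named here.

Measured compounds:
Compound 2, `CS(=O)(=O)Nc1ccc(-n2cc(COc3ccc4ccccc4c3)nn2)cc1Oc1ccccc1`, gives 19500 nM in a functional assay on HepG2 cells (Homo sapiens) for inhibition, read by MTT assay, with a stated time of 48 h; on this read-out lower numbers stand for stronger inhibition and higher numbers for weaker inhibition.
Compound 3, `Cc1ccc(-c2cn(-c3ccc(NS(C)(=O)=O)c(Oc4ccccc4)c3)nn2)cc1`, gives 18300 nM in this assay.
Compound 1, `CS(=O)(=O)Nc1ccc(-n2cc(COc3ccc([N+](=O)[O-])cc3)nn2)cc1Oc1ccccc1`, gives "not determined" (no result reported) in this assay.

Compound 1 therefore stands nowhere on the numbers shown; its own potency is unknown, and nothing can be said of it beyond its structure. The two values of compound 2 and compound 3 are within the usual scatter of each other, so neither is set apart from the other.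

Compound 4, `CS(=O)(=O)Nc1ccc(-n2cc(COc3ccc(Cl)cc3)nn2)cc1Oc1ccccc1`, follows from compound 1 by chloro in place of nitro on an aromatic carbon: a chloro in place of a nitro, on an aromatic carbon of a six-membered aromatic ring of carbon only. Going by the values given here, no step between measured compounds speaks to this change, so no direction is expected for it in this assay beyond the scatter, and the only guide is the level of compound 2 and compound 3. Compound 4 is accordingly expected near 18000 nM, within 6000 nM to 55000 nM.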

Compound 4, half-maximal inhibitory concentration: 7500 nM
Compound 4: the middle estimate sits 2.4-fold (0.38 log units) above what was measured; the measured number falls inside the stated range.
By their numbers in this assay, from the lowest: compound 4; then compounds 3 and 2 (each within the scatter of the next).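

In this assay, going by these compounds alone, compound 4 is the first compound set apart from the others, with 4-chlorophenyl in place of naphthalen-2-yl on the oxygen (a 2.6-fold lower number from compound 2 to compound 4 (0.41 log units; beyond the scatter)) and (4-chlorophenoxy)methyl in place of 4-methylphenyl on the aromatic carbon (a 2.4-fold lower number from compound 3 to compound 4 (0.39 log units; beyond the scatter)). Both steps are modest, so the position tolerates a change of group and the number moves only a little. Compound 1 gives ("not determined" (no result reported)), so chloro in place of nitro cannot be read as a step, and no evidence bears on the lower number.

On these data alone, whether fluoro, methoxy or an amine in that same place would match compound 4 remains open. So does the effect of a longer chain in place of the (4-chlorophenoxy)methyl group.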